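A few compounds are considered here, and "the series" means these few. Any claim that something is new, unique, unknown or untested is made for them only; others in the source may bear on it.

Among the compounds with values here, in a functional assay on PC-3 cells (Homo sapiens) for cytotoxicity, read by WST assay, with a stated time of 48 h (a higher number here means a weaker inhibitor, a lower number a stronger inhibitor), compound 1 `COc1ccc2c(/C=C(\C#N)C(=O)c3c[nH]c4cc(OC)ccc34)c[nH]c2c1` gives 27000 nM, the higher of the two numbers measured so far, and compound 2 `COc1ccc2c(/C=C(\C#N)C(=O)c3c[nH]c4ccccc34)c[nH]c2c1` gives 12500 nM. Compound 3 `COc1ccc2c(C(=O)/C(C#N)=C/c3c[nH]c4cc(F)ccc34)c[nH]c2c1` is still unmeasured, and its change from compound 1 is this: fluoro in place of methoxy on an aromatic carbon. Within the data shown here, only one measured step bears on it, which also removes a methoxy, with hydrogen entering in its place: a 2.2-fold lower number from compound 1 to compound 2 (0.33 log units; beyond the scatter), a modest step. Fluoro is not hydrogen, so this is a rough guide, but a similar modest drop toward a lower number is expected in this assay. The expected step is a 2.1-fold lower number from compound 1 to compound 3 (0.32 log units; beyond the scatter). For compound 3 the estimated value is 13000 nM, with an expected range of 5500 nM to 30000 nM.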

Compound 3, half-maximal inhibitory concentration: 22500 nM
For compound 3 the middle estimate is 1.7-fold (0.24 log units) below the measured one; low and high end bracket the measured number.
By their numbers in this assay, from the lowest: compounds 2, 3 and 1 (each within the scatter of the next, the first and the last beyond it).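

In this assay fluoro in place of methoxy gives a 1.2-fold lower number from compound 1 to compound 3 (0.08 log units; within the scatter) and so the two groups cannot be told apart at this aromatic carbon. The methoxy replaced here is not the one that hydrogen replaced in compound 2, so the earlier step (a 2.2-fold lower number from compound 1 to compound 2 (0.33 log units; beyond the scatter)) describes a different carbon. No measurement at hand offers an explanation for this result.

From the compounds shown here alone, what hydrogen would do at this same carbon remains open. So does whether an amine or a longer chain such as butoxy here would move the number beyond the scatter.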